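The source may report more compounds than this note shows. Statements on the series, on what has been measured and on what is new or still open speak of the compounds shown alone.

Compound 1 `CC1(C)CC(=O)C(C(=S)SCc2ccccc2)=C(Nc2ccc(Cl)cc2Cl)C1` and compound 2 `CC1(C)CC(=O)C(C(=S)SCCO)=C(Nc2ccc(Cl)cc2Cl)C1` share one core and differ in a single place. In a functional assay on cells (blood, Homo sapiens) for inhibition, read by chemiluminescence, with a stated time of 30 min (a higher number here means a weaker inhibitor, a lower number a stronger inhibitor), compound 1 gives only a limit, > 100 ug/mL, and not a number. In this assay compound 2 likewise gives only a limit, > 100 ug/mL. The step between them, a step that the two limits leave unreadable from compound 1 to compound 2, cannot be read because both values sit at the limit of > 100 ug/mL in this assay, at which 2 of the 2 values shown sit. Compound 3 `CC1(C)CC(=O)C(C(=S)SCCO)=C(Nc2ccc(Br)cc2)C1` has not yet been measured in this assay. It differs from compound 2 in one place: 4-bromophenyl in place of 2,4-dichlorophenyl on an amine nitrogen. Within the data shown here, no measured step touches the group that changes here, so the numbers so far give no direction for this change. The step that the limit leaves unreadable from compound 2 to compound 3 is therefore expected to be small, with a wide range around it. Compound 2 shows only a limit in this assay, and compound 1 shows only a limit too, so the most likely outcome is that compound 3 also reaches only that limit. The estimate for compound 3 in this assay is 150 ug/mL, between 40 ug/mL and 600 ug/mL.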

Compound 3, half-maximal inhibitory concentration: > 100 ug/mL
Compound 3: only a limit was reported; the forecaster's own chance of this, stated with the estimate: 75%; the middle value lies beyond the limit too.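

Compound 3, like compound 2, gives only a limit in this assay and not a number. No step can be read from compound 2 to compound 3, because both stand at the same limit: the limit of > 100 ug/mL in this assay, at which 3 of the 3 values shown sit.

The compounds shown leave open how strongly any of them inhibits, and whether the group on the sulfur or on the amine nitrogen matters at all.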